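Shortening the Selenium-Bearing Chain of Compound 1

The source may hold more compounds than are shown below. What is called first, only, known or untested is meant among the compounds shown, and "the series" means these compounds.

Measured in a functional assay on A549 cells (Homo sapiens) for inhibition, read by MTT assay, with a stated time of 48 h; a higher number here means a weaker inhibitor, a lower number a stronger inhibitor:
- compound 1 `COc1ccc(N(C)c2nc(C)nc3ccccc23)cc1OCCC[Se]C#N`: 382 nM
- compound 2 `COc1ccc(N(C)c2nc(C)nc3ccccc23)cc1OCCCCCC[Se]C#N`: 5520 nM
- compound 3 `COc1ccc(N(C)c2nc(C)nc3ccccc23)cc1C(=O)NCC[Se]C#N`: 187 nM

Of these three, compound 1 holds the middle place, with the second highest number. Compound 4 `COc1ccc(N(C)c2nc(C)nc3ccccc23)cc1OCC[Se]C#N`, not yet measured, differs from it on a saturated chain carbon, two bonds along the chain from an oxygen on an aromatic ring: a group of 3 heavy atoms (1 carbon, 1 nitrogen, 1 selenium; no ring) in place of a group of 4 heavy atoms (2 carbon, 1 nitrogen, 1 selenium; no ring), on a saturated chain carbon, two bonds along the chain from an oxygen on an aromatic ring. The closest evidence is the large 14-fold higher number from compound 1 to compound 2 (1.16 log units; beyond the scatter), which comes from a longer chain. The modest 2.0-fold lower number from compound 1 to compound 3 (0.31 log units; beyond the scatter) goes with a change on an aromatic carbon. It bears only indirectly. For the measured compounds named here, no measured compound has a shorter chain on this oxygen. The expected step in this assay is therefore small and not beyond the scatter, a 1.3-fold lower number from compound 1 to compound 4 (0.12 log units; within the scatter). For compound 4 the estimated value is 290 nM, with an expected range from 100 nM to 850 nM.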

Compound 4, half-maximal inhibitory concentration: 13 nM
Beside the measured number, compound 4's estimate is 22-fold (1.35 log units) above it; the measured number lies below the stated range.
By their numbers in this assay, from the lowest: compound 4; then compound 3; then compound 1; then compound 2.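

In this assay, the shorter chain gives a 29-fold lower number from compound 1 to compound 4 (1.47 log units; beyond the scatter), showing that this position responds strongly in both directions, and the number rises with chain length across the oxygen-linked compounds, with a 420-fold lower number from compound 2 to compound 4 (2.63 log units; beyond the scatter) overall. The shorter chain on the oxygen also outdoes the amide-linked chain, with a 14-fold lower number from compound 3 to compound 4 (1.16 log units; beyond the scatter). Nothing available here accounts for these steps.

The compounds shown leave open whether a sulfur atom in place of the selenium would keep the number of compound 4. They also leave open whether a longer chain on the amide of compound 3 would follow the same trend.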